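The source may report more compounds than this note shows. Statements on the series, on what has been measured and on what is new or still open speak of the compounds shown alone.

Measured compounds and their results:
- Compound 1, `COc1cc(-c2cc(/C=C/C(=O)c3ccc(N)cc3)[nH]n2)cc(OC)c1OC`, gives 13400 nM in a functional assay on A498 cells (Homo sapiens) for inhibition, read by sulforhodamine B assay, with a stated time of 48 h; a higher number here means that more compound is tolerated, a lower number that less compound is tolerated.
- Compound 2, `COc1cc(-c2cc(/C=C/C(=O)c3ccc(Cl)c(Cl)c3)[nH]n2)cc(OC)c1OC`, gives in this assay only a limit of the assay, > 100000 nM.
- Compound 3, `COc1ccc(-c2cc(/C=C/C(=O)c3cc(OC)c(OC)c(OC)c3)[nH]n2)cc1OC`, gives 22300 nM in this assay.

Compound 3 has the highest of the two numbers, but its gap to compound 1 is within the usual scatter, so the two cannot be told apart on these data. Compound 2 stands apart in giving a limit only; (the limit of > 100000 nM in this assay, at which 1 of the 3 values shown sits).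

Compound 4, `COc1cc(C(=O)/C=C/c2cc(-c3cc(OC)c(OC)c(OC)c3)n[nH]2)cc(OC)c1OC`, differs from compound 3 in one place: methoxy in place of hydrogen on an aromatic carbon. Going by the values given here, the only measured step, an at least 7.4-fold higher number from compound 1 to compound 2 (0.87 log units; beyond the scatter), concerns the ring attached to the carbonyl carbon, which is not the ring changed here, so no measured step bears directly on this change. With nothing pointing either way, the expectation is a step of a 1.1-fold higher number from compound 3 to compound 4 (0.05 log units; within the scatter), that is, none beyond the scatter. Compound 4 is therefore estimated at 25000 nM, within a range from 8000 nM to 80000 nM.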

Compound 4, concentration lethal to 50% of the cells: 8020 nM
The estimate for compound 4 lay 3.1-fold (0.49 log units) above the measured number; the measured number falls inside the stated range.
By their numbers in this assay, from the lowest: compounds 4, 1 and 3 (each within the scatter of the next, the first and the last beyond it). At a limit, above all of these: compound 2.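

Placing methoxy in place of hydrogen on this aromatic carbon, ortho to a methoxy group and meta to a large group, brings a 2.8-fold lower number from compound 3 to compound 4 (0.44 log units; beyond the scatter) in this assay, so less compound is tolerated. Going by these compounds alone, this is the first measured step on the ring that is not attached to the carbonyl carbon, and it shows that this position is not silent: one small addition there moves the number beyond the scatter. Nothing measured here explains why this change acts as it does.

The compounds shown leave open whether this step belongs to methoxy itself or would also appear with a hydroxyl, an amine or a chlorine at this position. They also leave open whether the same addition would act alike with a 4-aminophenyl on the carbonyl carbon.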